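The source may hold more compounds than are shown below. What is called first, only, known or untested is meant among the compounds shown, and "the series" means these compounds.

In a functional assay on NCI-H460 cells (Homo sapiens) for antiproliferative activity, read by sulforhodamine B assay, with a stated time of 72 h (a higher number here means a weaker inhibitor, a lower number a stronger inhibitor), compound 3 `Cc1cc(NS(=O)(=O)c2ccc(Nc3nncc4ccccc34)cc2)no1` gives 28 nM, within the scatter of compound 2 `O=S(=O)(Nc1ccccn1)c1ccc(Nc2nncc3ccccc23)cc1` at 43 nM, while compound 1 `Cc1cc(C)nc(NS(=O)(=O)c2ccc(Nc3nncc4ccccc34)cc2)n1` stands well apart at 0.8 nM. The next change leads to compound 4 `NS(=O)(=O)c1ccc(Nc2nncc3ccccc23)cc1`, with hydrogen in place of 5-methyl-1,2-oxazol-3-yl on a sulfonamide nitrogen. The closest evidence comes from exchanges of that substituent. Two were large, a 54-fold higher number from compound 1 to compound 2 (1.73 log units; beyond the scatter) and a 35-fold higher number from compound 1 to compound 3 (1.54 log units; beyond the scatter), whereas a 1.5-fold lower number from compound 2 to compound 3 (0.19 log units; within the scatter) stayed within the scatter. None of these removes the substituent outright, so they offer only a loose guide. A moderately higher number is expected in this assay, with a wide margin. The estimated step is a 2.9-fold higher number from compound 3 to compound 4 (0.46 log units; beyond the scatter). Compound 4 is estimated at 80 nM, with an expected range of 15 nM to 400 nM.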

Compound 4, half-maximal inhibitory concentration: 17 nM
Compound 4: the middle estimate sits 4.7-fold (0.67 log units) above what was measured; measured number inside the range.
By their numbers in this assay, from the lowest: compound 1; then compounds 4, 3 and 2 (each within the scatter of the next, the first and the last beyond it).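

Removing the substituent outright leaves the plain sulfonamide in the same range as the 5-methyl-1,2-oxazol-3-yl compound (a 1.6-fold lower number from compound 3 to compound 4 (0.22 log units; within the scatter)) and modestly apart from the pyridin-2-yl compound (a 2.5-fold lower number from compound 2 to compound 4 (0.40 log units; beyond the scatter)). A ring on this sulfonamide nitrogen is therefore not needed for a number in this range, and among the groups shown only 4,6-dimethylpyrimidin-2-yl stands clearly apart from hydrogen (a 21-fold higher number from compound 1 to compound 4 (1.33 log units; beyond the scatter)). No measured property is available to account for these steps.

As far as these compounds go, whether compound 1 depends on both methyl groups stays open. Also open, from the compounds shown here alone, is how an unsubstituted pyrimidin-2-yl or an acetyl group on this nitrogen would compare.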